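Methoxy at a New Place on the Shared Core

The compounds below may be only part of what the source reports. "The series", "measured", "known", "first", "only" and "open" are said of these compounds alone.

Of the compounds shown here, three have been measured in a functional assay on the whole organism with Rattus norvegicus as the target; on this read-out lower numbers stand for an effect already at smaller amounts and higher numbers for an effect only at larger amounts of compound. Compound 1 `COCCOC(=O)C(=O)Nc1nc(-c2cc(Br)no2)cs1` gives 7 mg/kg, and compound 2 `CCOC(=O)C(=O)Nc1nc(-c2cc(Br)no2)cs1` gives 12 mg/kg. Compound 1 differs from compound 2 by one change methoxy in place of hydrogen on a saturated chain carbon, two bonds along the chain from an oxygen next to a carbonyl group and the step of a 1.7-fold lower number from compound 2 to compound 1 (0.23 log units; within the scatter) is within the scatter, so the two values show no difference of rank. Compound 3 `CCOCCOC(=O)C(=O)Nc1nc(-c2cc(C)no2)cs1` gives 0.04 mg/kg, the lowest of the three numbers and beyond the scatter from both others. How the core of compound 3 differs from that of compound 2 is not broken down here.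

Compound 4 `CCOCCOC(=O)C(=O)Nc1nc(-c2cc(COC)no2)cs1` has not been measured. It differs from compound 3 by methoxy in place of hydrogen on a saturated chain carbon bound to an aromatic carbon. This is the same kind of change as that from compound 2 to compound 1, but the place is not the same: there the methoxy entered on a saturated chain carbon two bonds along the chain from an oxygen next to a carbonyl group, here on a saturated chain carbon bound to an aromatic carbon. Given that the earlier step of a 1.7-fold lower number from compound 2 to compound 1 (0.23 log units; within the scatter) stayed within the scatter, the expected step of a 1.3-fold higher number from compound 3 to compound 4 (0.10 log units; within the scatter) is estimated to be small in this assay. Compound 4 is therefore estimated at 0.05 mg/kg, expected to lie between 0.015 mg/kg and 0.2 mg/kg.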

Compound 4, dose for half-maximal effect: 2.4 mg/kg
Beside the measured number, compound 4's estimate is 48-fold (1.68 log units) below it; the whole stated range lies below it.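

In this assay, the methoxy change was far from neutral on the core of compound 3, giving a 60-fold higher number from compound 3 to compound 4 (1.78 log units; beyond the scatter). Set beside the earlier step, the change did not carry over from one core to the other: the same change on two cores in this assay, a 1.7-fold lower number (0.23 log units; within the scatter) from compound 2 to compound 1 and a 60-fold higher number (1.78 log units; beyond the scatter) from compound 3 to compound 4, 100-fold (2.01 log units) apart, beyond the scatter of two such steps. This does not show why the two steps part, as the methoxy enters at a different place in each, here on a saturated chain carbon bound to an aromatic carbon, and a single pair on each core cannot separate the effect of place from that of core.

The compounds shown leave open whether the large step belongs to the methoxymethyl group itself or would come with other groups at this place, such as ethyl, hydroxymethyl or aminomethyl in place of the methyl. From the compounds shown here alone, it also remains open whether a longer chain ether, such as ethoxymethyl, would move the number further in the same direction.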